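Swapping One Ring Stereocentre in a Chemokine Receptor Agonist Series

The source may hold more compounds than are shown below. What is called first, only, known or untested is meant among the compounds shown, and "the series" means these compounds.

Compound 1 `CN(C[C@H]1Cc2c(cccc2N2CCN(C3COC3)CC2)CN1)[C@H]1CCCc2cccnc21`: in a functional assay on CCRF-CEM cells for agonist activity at C-X-C chemokine receptor type 4 (Homo sapiens), read by calcium flux, with a stated time of 25 min (a lower number here means that less compound is needed, a higher number that more compound is needed for the effect), compound 1 gives > 30000 nM, which is a limit of the assay rather than a number.
Compound 2 `CN(C[C@H]1Cc2c(cccc2N2CCNCC2)CN1)[C@H]1CCCc2cccnc21`: in this assay compound 2 gives > 30000 nM, also a limit.
Compound 3 `CN(C[C@H]1Cc2c(cccc2N2CCN3CCC[C@@H]3C2)CN1)[C@H]1CCCc2cccnc21`: in this assay compound 3 gives > 30000 nM, again a limit.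

All three measured compounds share the same core and differ only in the group attached to one aromatic carbon. Because every value sits at the limit of > 30000 nM in this assay, at which 3 of the 3 values shown sit, none of the three steps can be sized: a step that the two limits leave unreadable from compound 1 to compound 2, a step that the two limits leave unreadable from compound 1 to compound 3 and a step that the two limits leave unreadable from compound 2 to compound 3 are all unreadable. Compound 3 therefore stands at the limit, with no measured potency to place it above or below its neighbours.

Compound 4 `CN(C[C@H]1Cc2c(cccc2N2CCN3CCC[C@H]3C2)CN1)[C@H]1CCCc2cccnc21` has not yet been measured. Its difference from compound 3 is the smallest possible: the two compounds have the same atoms and bonds and differ only in configuration as drawn: 1 of 3 stereo elements differ; a stereocentre at a saturated ring carbon is drawn R in compound 3 and S in compound 4. Among the measured compounds shown here, the two steps that touch compound 3 bear on this change only in showing that the whole series so far has stayed at the limit, so there is no measured step from which a direction or a size can be taken. The expectation for compound 4 is therefore that it, too, is most likely to return a limit, with an estimated value of 40000 nM (range 15000 nM to 150000 nM), which means an expected step that the limit leaves unreadable from compound 3 to compound 4.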

Compound 4, half-maximal effective concentration: > 30000 nM
Compound 4 ended at the assay's limit (the forecaster's own chance of this, stated with the estimate: 85%); the middle value is on the limit's open side.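

Among the compounds shown here, no step from compound 1, compound 2 or compound 3 to compound 4 can be read, since all four compounds stop at the same limit rather than at a number: the limit of > 30000 nM in this assay, at which 4 of the 4 values shown sit. As far as these compounds go, it remains open whether the stereocentre drawn R in compound 3 and S in compound 4, or any group on this aromatic carbon, changes potency in this assay.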